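The compounds below may be only part of what the source reports. "The series", "measured", "known", "first", "only" and "open" are said of these compounds alone.

Working notes on the series, all in a functional assay on KBVIN cells (Homo sapiens) for cytotoxicity, read by MTT assay, with a stated time of 72 h; on this read-out lower numbers stand for an effect already at smaller amounts and higher numbers for an effect only at larger amounts of compound:

- compound 1 `CCc1cccc2c(OC)c(-c3occ(C)c3C(=O)OC)ccc12` gives 1.3 ug/mL
- compound 2 `CCOc1c(-c2occ(C)c2C(=O)OC)ccc2c(CC)cccc12` gives 1.7 ug/mL

Compound 2 stands at the higher of the two numbers, but only marginally: the step of a 1.3-fold higher number from compound 1 to compound 2 (0.12 log units; within the scatter) is within the scatter, so the two compounds cannot be told apart on this read-out.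

Compound 3 `CCOc1c(-c2occ(C)c2CO)ccc2c(CC)cccc12` is not yet measured. It differs from compound 2 in one place: hydroxymethyl in place of methoxycarbonyl on an aromatic carbon. Going by the values given here, the single measured step in this set, from compound 1 to compound 2, concerns the group on the oxygen of the aromatic ring and does not touch the five-membered ring, so no measured step bears on this change. There is therefore nothing in the data to anchor the direction or the size of the expected step; a change in the five-membered ring's substituent from an ester to a hydroxymethyl is an untested move here.

For compound 3 the estimated step is a 1.8-fold higher number from compound 2 to compound 3 (0.25 log units; within the scatter), stated with wide margins. Compound 3 is expected to give about 3 ug/mL, in the range 0.8 ug/mL to 12 ug/mL.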

Compound 3, concentration for half-maximal effect: 6.4 ug/mL
For compound 3 the middle estimate is 2.1-fold (0.33 log units) below the measured one; low and high end bracket the measured number.
By their numbers in this assay, from the lowest: compounds 1 and 2 (each within the scatter of the next); then compound 3.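

In this assay, going by these compounds alone, hydroxymethyl in place of methoxycarbonyl on the five-membered aromatic ring with 1 oxygen gives a 3.8-fold higher number from compound 2 to compound 3 (0.58 log units; beyond the scatter), the first step in this set to lie beyond the scatter. Within the data shown here, the change on the oxygen-bound chain, by contrast, gives a 1.3-fold higher number from compound 1 to compound 2 (0.12 log units; within the scatter), so the substituent on the five-membered ring is the one place so far where a single change separates two compounds on this read-out, though each place rests on one step only. The change does not abolish the effect, since compound 3 still gives a measurable 6.4 ug/mL, and nothing measured in this set accounts for the shift.

Open, as far as these compounds go, is whether the higher number follows the departure of methoxycarbonyl or the arrival of hydroxymethyl, a question that a carboxylic acid, a primary amide or a longer ester such as ethoxycarbonyl at the same ring carbon would help to settle. Also open, from the compounds shown here alone, is whether hydroxymethyl in place of methoxycarbonyl on the core of compound 1, with its smaller group on the oxygen, would give a step of similar size.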